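Cyclohexyl to Ethyl on an Amide: Cytotoxicity Outlook

The source may report more compounds than this note shows. Statements on the series, on what has been measured and on what is new or still open speak of the compounds shown alone.

Compound 2 `O=C(NC1CCCCC1)c1cccn1-c1ccc2c(c1)B(O)OC2` was tested in an ADME assay on L929 cells (Mus musculus) for cytotoxicity, read by resazurin assay, with a stated time of 72 h; a lower number here means a stronger inhibitor, a higher number a weaker inhibitor. In this assay compound 2 gives > 10 ug/mL, which is a limit of the assay rather than a number. Compound 1 `OB1OCc2ccc(-n3cc(Sc4ccc(Cl)c(Cl)c4)c4ccccc43)cc21` was tested in the same way; in this assay compound 1 gives > 10 ug/mL, likewise a limit. Both results stand at the limit of > 10 ug/mL in this assay, at which 2 of the 2 values shown sit. Compound 3 `CCNC(=O)c1cccn1-c1ccc2c(c1)B(O)OC2` differs from compound 2 by ethyl in place of cyclohexyl on an amide-type nitrogen. Among the measured compounds shown here, no measured step of this kind exists, so the change is expected to make no difference beyond the scatter, as a step that the limit leaves unreadable from compound 2 to compound 3. Compound 3 is therefore estimated to give 20 ug/mL, between 8 ug/mL and 60 ug/mL.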

Compound 3, half-maximal inhibitory concentration: > 10 ug/mL
Compound 3: a limit, no number; the forecaster's own chance of this, stated with the estimate: 85%; the middle value lies beyond the limit too.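

Among the compounds shown here, compound 2 and compound 3 both give only a limit, not a number, so no step between them can be read: (the limit of > 10 ug/mL in this assay, at which 3 of the 3 values shown sit). On these data alone, whether ethyl in place of cyclohexyl changes cytotoxicity at all remains open.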